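The source may report more compounds than this note shows. Statements on the series, on what has been measured and on what is new or still open speak of the compounds shown alone.

Of the compounds shown here, three built on the same shared core have been measured. Compound 1 `O=C(CI)NCCCCCC(=O)NCCCCCCNc1ncnc2c1ncn2[C@@H]1O[C@H](COP(=O)(O)OP(=O)(O)OP(=O)(O)O)[C@@H](O)[C@H]1O` gives 0% in an assay on isolated protein for inhibition of hexokinase-3 (Rattus norvegicus), with a stated time of 6 h, tested at 10 mM; on this read-out higher numbers stand for more inhibition at the one concentration tested (going by the name of the read-out) and lower numbers for less inhibition. Compound 2 `O=C(CI)NCCCCCCC(=O)NCCCCCCNc1ncnc2c1ncn2[C@@H]1O[C@H](COP(=O)(O)OP(=O)(O)OP(=O)(O)O)[C@@H](O)[C@H]1O` gives 0% in this assay, and compound 3 `O=C(CI)NCCC(=O)NCCCCCCNc1ncnc2c1ncn2[C@@H]1O[C@H](COP(=O)(O)OP(=O)(O)OP(=O)(O)O)[C@@H](O)[C@H]1O` gives 0% in this assay. The steps among them, no change at the digits printed from compound 1 to compound 2 (within the scatter), no change at the digits printed from compound 1 to compound 3 (within the scatter) and no change at the digits printed from compound 2 to compound 3 (within the scatter), all lie within the scatter, so compound 3 stands level with compound 1 and compound 2 on the numbers shown, with no compound standing apart.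

Compound 4 `CC(=O)NCCCCCCCCNc1ncnc2c1ncn2[C@@H]1O[C@H](COP(=O)(O)OP(=O)(O)OP(=O)(O)O)[C@@H](O)[C@H]1O` is the next compound to be measured. Its change from compound 3 is a group of 6 heavy atoms (4 carbon, 1 nitrogen, 1 oxygen; no ring) in place of a group of 10 heavy atoms (5 carbon, 2 nitrogen, 2 oxygen, 1 iodine; no ring), on a saturated chain carbon, six bonds along the chain from a nitrogen on an aromatic ring. The measured steps that bear on this change are those that alter the chain between the two amide groups, and each of them, no change at the digits printed from compound 1 to compound 3 (within the scatter) and no change at the digits printed from compound 2 to compound 3 (within the scatter), was no change within the scatter. Among the compounds with values here, the change to compound 4 goes further, exchanging the whole group that carries the iodine, and no measured step covers that exchange. Nothing among the measured compounds gives a reason to expect a step beyond the scatter, and the account therefore expects no change at the digits printed from compound 3 to compound 4 (within the scatter) to stay within the scatter. In this assay compound 4 is expected to give 0%, within the range 0% to 10%.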

Compound 4, a percentage reported as inhibition, at one concentration (the size of the read-out at that concentration, not a potency): 0%
For compound 4 middle estimate and measured number coincide at the digits printed; the measured number falls inside the stated range.
By their numbers in this assay, from the lowest: compounds 1, 2, 3 and 4 (each within the scatter of the next).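

The earlier steps shown here only altered the length of the chain and kept the iodine-bearing end, whereas this one exchanges that whole group for 2-acetamidoethyl, on a saturated chain carbon, six bonds along the chain from a nitrogen on an aromatic ring. In this assay, that larger exchange gives no change at the digits printed from compound 3 to compound 4 (within the scatter), so at this position the read-out separates the iodine-free compound 4 from the iodine-bearing compounds no more than it separates those compounds from one another. Since compound 4 gives 0%, the iodine-bearing group cannot be credited with any inhibition on these numbers, and nothing measured here offers an explanation for the flat result.

With all four compounds at the same reading, the compounds shown leave open whether this assay would respond to any change at this position, as none of them gives a reading from which a loss could be seen. From the compounds shown here alone, it also remains open whether a primary amine or a carboxylic acid in place of 2-acetamidoethyl, or a chain longer than that of compound 2 carrying the iodine-bearing group, would give a reading that stands apart from these four.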